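The compounds below may be only part of what the source reports. "The series", "measured", "known", "first", "only" and "open" are said of these compounds alone.

Compound 1 `CCC(CC)O[C@@H]1C=C(C(=O)O)C[C@H](NCc2ccc(C(C)C)cc2)[C@H]1NC(C)=O`: > 200000 nM (a limit)
Compound 2 `CCC(CC)O[C@@H]1C=C(C(=O)O)C[C@H](NCc2ccc(OC(C)C)cc2)[C@H]1NC(C)=O`: > 200000 nM (a limit)

Both entries come from an ADME assay on cells (Fibroblast, Gallus gallus) for cytotoxicity, read by CCK-8 assay, with a stated time of 48 h; a higher number here means that more compound is tolerated, a lower number that less compound is tolerated. Among the measured compounds shown here, compound 2 is known only by its limit of > 200000 nM, and the same holds for the one other compound measured: the limit of > 200000 nM in this assay, at which 2 of the 2 values shown sit. Compound 3 `CCC(CC)Oc1ccc(CN[C@H]2CC(C(=O)O)=C[C@@H](OC(CC)CC)[C@@H]2NC(C)=O)cc1` differs from compound 2 by one change: pentan-3-yl in place of isopropyl on an oxygen on an aromatic ring. For the measured compounds named here, the only measured step that bears on it is a step that the two limits leave unreadable from compound 1 to compound 2, where isopropoxy takes the place of isopropyl on an aromatic carbon. That step offers no size to carry over, so no direction is favoured, and no change beyond the usual scatter is expected in this assay. Compound 3 will probably also reach the limit. The expected step is a step that the limit leaves unreadable from compound 2 to compound 3. Compound 3 is estimated at 220000 nM, with an expected range from 100000 nM to 400000 nM.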

Compound 3, half-maximal cytotoxic concentration: > 200000 nM
Compound 3: only a limit was reported; the forecaster's own chance of this, stated with the estimate: 85%; the middle value is on the limit's open side.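

Among the compounds shown here, compound 3 is likewise known only by a limit, > 200000 nM, and no step among compound 1, compound 2 and compound 3 can be read. The compounds shown leave open how far each lies beyond that limit, and whether their isopropyl, isopropoxy and (pentan-3-yl)oxy groups differ in tolerance at all.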